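The source may report more compounds than this note shows. Statements on the series, on what has been measured and on what is new or still open speak of the compounds shown alone.

Compound 1 `CC(C)(C)OC(=O)N1CCC(n2ncc3cc(-c4ccc(S(C)(=O)=O)cc4)ncc32)CC1` is one of three measured members of a shared core. In a functional assay on HEK293 cells for agonist activity at Glucose-dependent insulinotropic receptor (Homo sapiens), read by cAMP accumulation, with a stated time of 30 min (a lower number here means that less compound is needed, a higher number that more compound is needed for the effect), compound 1 gives 20 nM, the second highest of the three numbers. Compound 3 `CCCNC(=O)c1cc(F)c(-c2cc3cnn(C4CCN(C(=O)OC(C)C)CC4)c3cn2)cc1F` gives 14 nM, within the scatter of compound 1, while compound 2 `CC(C)OC(=O)N1CCC(n2ncc3cc(-c4cc(F)c(C(=O)N(C)C)cc4F)ncc32)CC1` gives 46 nM, higher than compound 1 beyond the scatter. Within the data shown here, the only measured step, a 3.3-fold lower number from compound 2 to compound 3 (0.52 log units; beyond the scatter), concerns the amide end of the molecule and does not touch the carbamate. Compound 4 `CC(C)(OC(=O)N1CCC(n2ncc3cc(-c4ccc(S(C)(=O)=O)cc4)ncc32)CC1)C(F)F` differs from compound 1 by difluoromethyl in place of methyl on a saturated chain carbon bound to an oxygen next to a carbonyl group and two saturated chain carbons. Among the measured compounds shown here, no measured step bears on this change, so for compound 4 a step of no change at the digits printed from compound 1 to compound 4 (within the scatter) in this assay is expected, that is, none beyond the scatter. Compound 4 is therefore estimated at 20 nM, between 8 nM and 50 nM.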

Compound 4, half-maximal effective concentration: 23 nM
Compound 4: the middle estimate sits 1.2-fold (0.06 log units) below what was measured; low and high end bracket the measured number.
By their numbers in this assay, from the lowest: compounds 3, 1, 4 and 2 (each within the scatter of the next, the first and the last beyond it).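

In this assay, the change from tert-butyl to 1-(difluoromethyl)-1-methylethyl gives a 1.2-fold higher number from compound 1 to compound 4 (0.06 log units; within the scatter). Among these compounds, this is the first reading at this position, which the earlier step did not touch, and it shows that difluoromethyl can stand in place of methyl here with no shift beyond the scatter. Nothing available explains this result. Going by these compounds, what a trifluoromethyl group, a hydroxyl group or an amine on that carbon would do remains open. So does whether difluoromethyl behaves the same way with the fluorinated amide end of compound 3.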